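The source may report more compounds than this note shows. Statements on the series, on what has been measured and on what is new or still open speak of the compounds shown alone.

The three measured compounds share one core. Compound 1 `COC(=O)CCCNC(=O)CN1CN(c2ccccc2)C2(CCN(C(=O)c3ccc(C4CCCCC4)cc3)CC2)C1=O` gives 2500 nM in an assay on HEK293 cells for displacement of a labelled ligand from NPC1-like intracellular cholesterol transporter 1 (Homo sapiens); on this read-out lower numbers stand for stronger inhibition and higher numbers for weaker inhibition. Compound 2 `CC(C)(C)OC(=O)NC1CCCN(C(=O)CN2CN(c3ccccc3)C3(CCN(C(=O)c4ccc(C(C)(C)C)cc4)CC3)C2=O)C1` gives 4200 nM in this assay, and compound 3 `CC(C)(C)OC(=O)NC1CCCN(C(=O)CN2CN(c3ccccc3)C3(CCN(C(=O)c4ccc(C5CCCCC5)cc4)CC3)C2=O)C1` gives 4400 nM. Compound 2 stands second highest of these three numbers; its nearest neighbour is compound 3 and its furthest is compound 1, both within the scatter. Among the measured compounds shown here, the only measured step, a 1.0-fold higher number from compound 2 to compound 3 (0.02 log units; within the scatter), concerns cyclohexyl in place of tert-butyl on an aromatic carbon and lies within the scatter. Compound 4 `CCOC(=O)C1CCCN(C(=O)CN2CN(c3ccccc3)C3(CCN(C(=O)c4ccc(C(C)(C)C)cc4)CC3)C2=O)C1` differs from compound 2 elsewhere: ethoxycarbonyl in place of (tert-butoxycarbonyl)amino on a saturated ring carbon. For the measured compounds named here, no measured step touches that place, so nothing supports a shift beyond the scatter in this assay. Compound 4 is therefore expected to give 4200 nM, with a range of 2000 nM to 9000 nM. The expected step is no change at the digits printed from compound 2 to compound 4 (within the scatter).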

Compound 4, half-maximal inhibitory concentration: 8200 nM
For compound 4 the middle estimate is 2.0-fold (0.29 log units) below the measured one, and the stated range covers the measured number.
By their numbers in this assay, from the lowest: compounds 1, 2, 3 and 4 (each within the scatter of the next, the first and the last beyond it).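

Among the compounds shown here, this is the first measured change at the saturated ring carbon two ring bonds from the ring nitrogen: in this assay ethoxycarbonyl in place of (tert-butoxycarbonyl)amino gives a step that stays within the scatter (a 2.0-fold higher number from compound 2 to compound 4 (0.29 log units; within the scatter)). The exchange removes the hydrogen-bond donor and goes from 8 heavy atoms to 5 without a step beyond the scatter. Nothing available bears on this step. From the compounds shown here alone, whether a free amine or a carboxylic acid on this ring carbon would stay within the scatter remains open, as does whether ethoxycarbonyl gives the same result with cyclohexyl in place of tert-butyl.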